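Working notes: cytotoxicity of the series on Vero cells

A few compounds are considered here, and "the series" means these few. Any claim that something is new, unique, unknown or untested is made for them only; others in the source may bear on it.

Compound 1 `CCOC(=O)c1cc(/C=C/c2cccc(C(F)(F)F)c2)on1` has been tested in an ADME assay on Vero cells (Chlorocebus sabaeus) for cytotoxicity, with a stated time of 72 h; a lower number here means a stronger inhibitor, a higher number a weaker inhibitor; there compound 1 gives > 128000 nM, which is a limit of the assay and not a number. Compound 2 `CCOC(=O)c1cc(/C=C/c2c(Cl)ccc(C)c2F)on1` likewise returns only a limit in this assay, > 128000 nM. Both values shown therefore sit at the limit of > 128000 nM in this assay, at which 2 of the 2 values shown sit. Compound 3 `CCOC(=O)c1cc(/C=C/c2cccc(O)c2)on1` is not yet measured; it differs from compound 1 by hydroxy in place of trifluoromethyl on an aromatic carbon. With every value shown resting at the limit, no step beyond the scatter is expected in this assay between compound 1 and compound 3, and a further limit seems the most probable outcome. The estimate for compound 3 is 150000 nM, within 64000 nM to 400000 nM. This estimate corresponds to an expected step that the limit leaves unreadable from compound 1 to compound 3.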

Compound 3, half-maximal inhibitory concentration: > 128000 nM
Compound 3 gave a limit, no number; the forecaster's own chance of this, stated with the estimate: 85%; the middle value does not contradict the limit.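

No step can be read between compound 1 and compound 3 in this assay: the limit of > 128000 nM in this assay, at which 3 of the 3 values shown sit.

The compounds shown leave open how hydroxy and trifluoromethyl compare in this assay, and at what concentration, if any, cytotoxicity would appear.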